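The source may hold more compounds than are shown below. What is called first, only, known or untested is meant among the compounds shown, and "the series" means these compounds.

For the measured compounds named here, compound 1 `Cc1cc2nn(-c3ccccc3)c(N)c2c(=O)[nH]1` gives 5% in an assay on isolated protein for inhibition of RAC-alpha serine/threonine-protein kinase (Homo sapiens), read by mobility shift assay, tested at 30 uM (a higher number here means more inhibition at the concentration tested (going by the name of the read-out), a lower number less inhibition), the highest of the two numbers measured so far; the nearest is compound 2 `Nc1c2c(=O)[nH]c(-c3ccccc3)cc2nn1-c1ccccc1`, which gives -2% in this assay, and the step of a number 7 percentage points lower from compound 1 to compound 2 (within the scatter) lies within the scatter. Compound 3 `Cc1[nH]c(=O)c2c(N)n(-c3ccccc3)nc2c1-c1ccccc1` is compound 1 with phenyl in place of hydrogen on an aromatic carbon. Going by the values given here, the only measured step, phenyl in place of methyl on an aromatic carbon, was within the scatter and sits at a different place, so it bears on this change only loosely. No step beyond the scatter is therefore expected; the estimate for compound 3 is 5%, range -8% to 22%, an expected step of no change at the digits printed from compound 1 to compound 3 (within the scatter).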

Compound 3, a percentage reported as inhibition, at one concentration (the size of the read-out at that concentration, not a potency): -8%
Estimate against measurement, compound 3: 13 percentage points above; the measured number falls inside the stated range.
By their numbers in this assay, from the lowest: compounds 3, 2 and 1 (each within the scatter of the next, the first and the last beyond it).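

Phenyl in place of hydrogen on the aromatic carbon ortho to a methyl group gives the first step beyond the scatter in this assay, with a number 13 percentage points lower from compound 1 to compound 3 (beyond the scatter). The step is modest and downward, so at this position phenyl brings no gain in inhibition. Nothing available explains the drop. Open, from the compounds shown here alone, is whether an amine or a methoxy group on this carbon, or a carboxylic acid on the added phenyl, would give a different result. Going by these compounds, with readings at one concentration only, potency also remains open.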